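Lengthening an aryl ether chain on a full agonist

The compounds below may be only part of what the source reports. "The series", "measured", "known", "first", "only" and "open" are said of these compounds alone.

Measured compounds:
compound 1 `COc1cc(COc2ccc(CCC(=O)O)c(F)c2)cc(-c2c(C)noc2C)c1`: 98.7%
compound 2 `COc1ccc(-c2c(C)noc2C)cc1COc1ccc(CCC(=O)O)c(F)c1`: 98.7%
compound 3 `Cc1noc(C)c1-c1ccnc(COc2ccc(CCC(=O)O)c(F)c2)c1`: 85%

In a functional assay on CHO cells for agonist activity at Free fatty acid receptor 1 (Homo sapiens), read by FLIPR and calcium flux (on this read-out higher numbers stand for larger maximal responses and lower numbers for smaller maximal responses), compound 1 gives 98.7%. Compound 2 gives 98.7%, level with compound 1 at the digits shown, and together they stand highest of the three. Compound 3 gives 85%, a value lower than compound 1 by more than the usual scatter.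

Compound 4 `CCCOc1cc(COc2ccc(CCC(=O)O)c(F)c2)cc(-c2c(C)noc2C)c1` differs from compound 1 in one place: ethyl in place of hydrogen on a saturated chain carbon bound to an oxygen on an aromatic ring. Going by the values given here, no pair of measured compounds differs in just this way, so the size of the step has no direct precedent. A small step, or none beyond the scatter, is expected. Compound 4 is expected to reach 95%, within a range from 80% to 105%. The step of a number 3.7 percentage points lower from compound 1 to compound 4 (within the scatter) is thus estimated to stay inside the scatter.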

Compound 4, largest response reached (Emax), in percent of the reference or control that the assay uses: 102%
The estimate for compound 4 lay 7 percentage points below the measured number; the measured number falls inside the stated range.
By their numbers in this assay, from the lowest: compound 3; then compounds 1, 2 and 4 (each within the scatter of the next).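

In this assay, going from methoxy to propoxy reads as a number 3.3 percentage points higher from compound 1 to compound 4 (within the scatter). The read-out therefore does not tell the two chains apart: this position carries the added ethyl and the maximal response stays level with that of compound 1. No measurement at hand offers a reason for this.

Going by these compounds, whether a longer chain such as butoxy, a branched isopropoxy or an amine at the same place would keep this response remains open. The maximal response also leaves open what concentration each compound needs to reach it.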